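Swapping the benzyl substituent on a shared core

The source may hold more compounds than are shown below. What is called first, only, known or untested is meant among the compounds shown, and "the series" means these compounds.

Measured compounds:
Compound 1 `O=c1ccc(-c2ccc3cn[nH]c3c2)cn1Cc1cccc(C(F)(F)F)c1` — in an assay for inhibition of MAP kinase-interacting serine/threonine-protein kinase 1 (Homo sapiens), read by luminescence and ADP-Glo, with a stated time of 2 h (on this read-out higher numbers stand for weaker inhibition and lower numbers for stronger inhibition), compound 1 gives 40 nM.
Compound 2 `Nc1cccc(Cn2cc(-c3ccc4cn[nH]c4c3)ccc2=O)c1` — in this assay compound 2 gives 287 nM.

Compound 2 stands at the higher of the two numbers seen so far; its nearest neighbour is compound 1, and the change a 7.2-fold higher number from compound 1 to compound 2 (0.86 log units; beyond the scatter) separates them. Compound 3 `O=c1ccc(-c2ccc3cn[nH]c3c2)cn1Cc1ccccc1F` has not yet been measured. It differs from compound 2 by 2-fluorophenyl in place of 3-aminophenyl on a saturated chain carbon bound to an aromatic nitrogen. Among the compounds with values here, no measured step matches this exact exchange; the only step known, a 7.2-fold higher number from compound 1 to compound 2 (0.86 log units; beyond the scatter), shows that the group carried on this benzyl ring can move the number by a modest amount, with the amino-bearing compound 2 at the weaker end. Compound 3 carries no amino group, so a move back toward the number of compound 1 is expected, though not necessarily all the way. Compound 3 is therefore estimated at 90 nM, with a range of 30 nM to 300 nM. That estimate means an expected step of a 3.2-fold lower number from compound 2 to compound 3 (0.50 log units; beyond the scatter).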

Compound 3, half-maximal inhibitory concentration: 47 nM
The estimate for compound 3 lay 1.9-fold (0.28 log units) above the measured number; the range from low to high includes it.
By their numbers in this assay, from the lowest: compounds 1 and 3 (each within the scatter of the next); then compound 2.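

In this assay, replacing 3-aminophenyl with 2-fluorophenyl gives a 6.1-fold lower number from compound 2 to compound 3 (0.79 log units; beyond the scatter), which shows that the trifluoromethyl group is not required for a number in this range. Within the data shown here, compound 1 at 40 nM and compound 3 at 47 nM lie within the usual scatter of each other, so two different fluorine-bearing benzyl groups read alike, while 3-aminophenyl, the only one of the three groups with a hydrogen-bond donor, stands apart. Nothing available here explains why this change moves the number.

This step changes both the group and where it sits on the ring, so the compounds shown cannot separate those two changes. A 2-aminophenyl or 3-fluorophenyl group would pull them apart, and an unsubstituted phenyl would show whether fluorine matters at all.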